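The source may hold more compounds than are shown below. What is called first, only, known or untested is meant among the compounds shown, and "the series" means these compounds.

Of the compounds shown here, three sharing one core have been tested in a functional assay on MDA-MB-435 cells (Homo sapiens) for cytotoxicity, read by MTT assay, with a stated time of 72 h; a higher number here means a weaker inhibitor, a lower number a stronger inhibitor. Compound 1 `N[C@H]1CC[C@H](Nc2c(C(=O)NCc3ccco3)nc(Br)c3cccnc23)CC1` reaches only > 10000 nM, which is a limit of the assay and not a number. Compound 2 `C[C@@H](Nc1c(C(=O)NCc2ccc(F)cc2)nc(Br)c2cccnc12)c1ccccc1` likewise reaches only > 20000 nM, again a limit rather than a number. Compound 3 `N[C@H]1CC[C@H](Nc2c(C(=O)NCc3ccc(Oc4ccccc4)cc3)nc(Br)c3cccnc23)CC1` gives 4000 nM. Compound 2 therefore stands at the limit of > 20000 nM in this assay, at which 1 of the 3 values shown sits, the higher of the two limits recorded. Compound 1 sits at the limit of > 10000 nM in this assay, at which 1 of the 3 values shown sits. Among the measured compounds no pair differs in one place, so no measured step is available. Compound 4 `COC(=O)CNc1c(C(=O)NCc2ccc(F)cc2)nc(Br)c2cccnc12` is derived from compound 2 by (methoxycarbonyl)methyl in place of 1-phenylethyl on a nitrogen on an aromatic ring. Within the data shown here, with no measured step of this kind to draw on, the step from compound 2 to compound 4 in this assay is expected to be no larger than the scatter, in either direction. Compound 2 already sits at a limit, so compound 4 is expected to remain weak. The step of a number no higher from compound 2 to compound 4 (the limit leaves the size open) is thus the expected outcome. Compound 4 is estimated at 20000 nM, with a range from 6000 nM to 60000 nM.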

Compound 4, half-maximal inhibitory concentration: 10000 nM
Estimate against measurement, compound 4: 2.0-fold (0.30 log units) above, and the stated range covers the measured number.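

Placing (methoxycarbonyl)methyl in place of 1-phenylethyl on a nitrogen on an aromatic ring gives, in this assay, an at least 2.0-fold lower number from compound 2 to compound 4 (0.30 log units; that floor lies within the scatter). This is the only step that can be read among the compounds shown, and it shows that this position tolerates the loss of the aromatic ring and the defined stereocentre: compound 4 still gives a measured number, 10000 nM, and not a limit. The full size of the step stays unknown, since compound 2 has only a limit of the assay and not a number: the limit of > 20000 nM in this assay, at which 1 of the 4 values shown sits.

Still open, as far as these compounds go, is whether a carboxylic acid in place of the methyl ester, or a longer chain between the nitrogen and the ester, would change the number in this assay. Also open, from the compounds shown here alone, is whether the same change would give a similar step with the amide side chain of compound 3.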